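Trifluoromethoxy in Place of Bromo: An Expected Small Step

The source may report more compounds than this note shows. Statements on the series, on what has been measured and on what is new or still open speak of the compounds shown alone.

Two compounds share a common core and differ only in the group on a nitrogen on an aromatic ring. Compound 1 `CCC(=O)N(C)c1ccc2[nH]c(-c3n[nH]c4ccccc34)cc2n1` carries a propanoyl there, and in a functional assay on A549 cells (Homo sapiens) for antiproliferative activity, read by MTT assay, with a stated time of 72 h (a higher number here means a weaker inhibitor, a lower number a stronger inhibitor), compound 1 gives 15700 nM. Compound 2 `CN(c1ccc2[nH]c(-c3n[nH]c4ccccc34)cc2n1)S(=O)(=O)c1ccc(Br)cc1` carries a (4-bromophenyl)sulfonyl instead, and in this assay compound 2 gives 19700 nM. That swap produced a 1.3-fold higher number from compound 1 to compound 2 (0.10 log units; within the scatter). Among the two measured numbers compound 2 has the highest, with compound 1 as its only neighbour, the gap lying within the scatter. Compound 3 `CN(c1ccc2[nH]c(-c3n[nH]c4ccccc34)cc2n1)S(=O)(=O)c1ccc(OC(F)(F)F)cc1` is the next step: trifluoromethoxy in place of bromo on an aromatic carbon. Going by the values given here, no measured step touches this position, so the only guide is the one step from compound 1 to compound 2, which moved the number little even though the whole group on the nitrogen was exchanged. A step of about a 1.1-fold lower number from compound 2 to compound 3 (0.04 log units; within the scatter) is therefore expected, meaning no change beyond the scatter. Compound 3 is estimated at 18000 nM, within a range of 8000 nM to 40000 nM.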

Compound 3, half-maximal inhibitory concentration: 8000 nM
For compound 3 the middle estimate is 2.3-fold (0.35 log units) above the measured one; the measured number falls inside the stated range.
By their numbers in this assay, from the lowest: compounds 3, 1 and 2 (each within the scatter of the next, the first and the last beyond it).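

In this assay, going by these compounds alone, replacing bromo with trifluoromethoxy gives a 2.5-fold lower number from compound 2 to compound 3 (0.39 log units; beyond the scatter) and is the first step here to pass beyond the scatter, though only modestly. The earlier exchange of the whole group on the nitrogen gave a 1.3-fold higher number from compound 1 to compound 2 (0.10 log units; within the scatter) and stayed within the scatter, so this single swap on an aromatic carbon, para to a large group, shows that the number can respond to a change at this position. No measurement shown here bears on why the number moved.

As far as these compounds go, it remains open whether a methoxy, a chloro or an amine at this carbon would lower the number further, leave it unchanged or raise it. From the compounds shown here alone, it is also open whether a single pair can say anything general about this position, since only bromo and trifluoromethoxy are compared there.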